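A few compounds are considered here, and "the series" means these few. Any claim that something is new, unique, unknown or untested is made for them only; others in the source may bear on it.

Measured so far:
compound 1 `Nc1ccccc1NC(=O)c1ccc(CSC(=S)N2CCN(C3CCCCC3)CC2)cc1` — 31.7%
compound 2 `Nc1ccccc1NC(=O)c1ccc(CSC(=S)N2CCN(c3ccccc3F)CC2)cc1` — 18.7%

Going by the values given here, in a functional assay on A-375 cells (Homo sapiens) for antiproliferative activity, read by CCK-8 assay, with a stated time of 72 h, tested at 2 uM (a lower number here means a weaker effect, a higher number a stronger effect of the compound at the concentration tested), compound 2 stands lowest of the two measured compounds; the single measured step, a number 13 percentage points lower from compound 1 to compound 2 (beyond the scatter), separates it from its only neighbour. Compound 3 `N#Cc1ccc(N2CCN(C(=S)SCc3ccc(C(=O)Nc4ccccc4N)cc3)CC2)cc1` differs from compound 2 by 4-cyanophenyl in place of 2-fluorophenyl on an amine nitrogen in a ring. Among the compounds with values here, no measured step exchanges one aryl group for another on this ring nitrogen, so the one known step, which trades a cyclohexyl for an aryl group, bears only loosely on this change. Compound 3 is therefore expected to show a step of a number 1.3 percentage points higher from compound 2 to compound 3 (within the scatter) that stays within the scatter. The estimate for compound 3 is 20%, with a range from 5% to 40%.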

Compound 3, a percentage reported as inhibition, at one concentration (the size of the read-out at that concentration, not a potency): 41.4%
Compound 3: middle estimate off by 21.4 percentage points, on the low side; measured number above the stated range.
By their numbers in this assay, from the lowest: compound 2; then compounds 1 and 3 (each within the scatter of the next).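

In this assay the choice of aryl group on this ring nitrogen counts: 4-cyanophenyl in place of 2-fluorophenyl gives a number 22.7 percentage points higher from compound 2 to compound 3 (beyond the scatter) and so shows that an aryl group here need not sit low. Set against cyclohexyl, the same group gives a number 9.7 percentage points higher from compound 1 to compound 3 (within the scatter) and so does not separate compound 1 from compound 3 in this read-out. Nothing measured here explains the difference between these aryl groups.

As far as these compounds go, what a 4-fluorophenyl or a 2-cyanophenyl group on this nitrogen would give stays open. So does whether the nitrile itself or its place on the ring carries the step.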